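Chloro for hydrogen on two benzyl-linked purine cores

The compounds below may be only part of what the source reports. "The series", "measured", "known", "first", "only" and "open" are said of these compounds alone.

Measured so far in a functional assay on A549 cells (Homo sapiens) for cytotoxicity, read by sulforhodamine B assay, with a stated time of 48 h; a lower number here means that less compound is tolerated, a higher number that more compound is tolerated:
compound 1 `ClCc1ccc(Cn2cnc3c(Cl)ncnc32)cc1` gives 51300 nM;
compound 2 `ClCc1cccc(Cn2cnc3ncnc(Cl)c32)c1` gives 91200 nM;
compound 3 `ClCc1ccc(Cn2cnc3c(Cl)nc(Cl)nc32)cc1` gives 74100 nM.

Compound 3 arises from compound 1 by the change (chloro in place of hydrogen on an aromatic carbon), and the step of a 1.4-fold higher number from compound 1 to compound 3 (0.16 log units; within the scatter) shows that this replacement leaves the read-out essentially where it was. Compound 2 shares its atoms with compound 1 but joins them differently; the difference between the two cores is not broken down here, and the values of compound 1 and compound 2 lie within the scatter of each other.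

Compound 4 `ClCc1cccc(Cn2cnc3nc(Cl)nc(Cl)c32)c1` is not yet measured. It relates to compound 2 by the change (chloro in place of hydrogen on an aromatic carbon), which is the same change already seen from compound 1 to compound 3, made on the other core. For the measured compounds named here, with only one earlier example of this change, the expected step of a 1.4-fold higher number from compound 2 to compound 4 (0.14 log units; within the scatter) rests on the single observed step of a 1.4-fold higher number from compound 1 to compound 3 (0.16 log units; within the scatter), so compound 4 is estimated to sit close to compound 2. Compound 4 is therefore expected to give 125000 nM, with a range from 62000 nM to 250000 nM.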

Compound 4, concentration lethal to 50% of the cells: 55000 nM
Estimate against measurement, compound 4: 2.3-fold (0.36 log units) above; the whole stated range lies above it.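

In this assay the chloro in place of hydrogen, on the aromatic carbon between two ring nitrogen atoms, gives a 1.7-fold lower number from compound 2 to compound 4 (0.22 log units; within the scatter) and so stays within the usual scatter on this core as well. Set beside the earlier step, the two cores cannot be told apart for this change: the same change on two cores in this assay, a 1.4-fold higher number (0.16 log units; within the scatter) from compound 1 to compound 3 and a 1.7-fold lower number (0.22 log units; within the scatter) from compound 2 to compound 4, 2.4-fold (0.38 log units) apart, within the scatter of two such steps. The data therefore support carrying the change from one core to the other as a replacement that leaves this read-out essentially unmoved, but the opposite directions of the two small steps show no dependence on the core, and two pairs cannot show that the result would hold on any further core.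

On these data alone, all four compounds share a chloromethyl group and a ring chloro, so it remains open whether a hydroxymethyl group in place of the chloromethyl, or an amine in place of the ring chloro, would move the read-out beyond the scatter. Also open, as far as these compounds go, is whether chloro for hydrogen would remain as silent on a core carrying such a group.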